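Replacing a trifluoromethylphenyl group with a methoxyphenylamino group

The source may report more compounds than this note shows. Statements on the series, on what has been measured and on what is new or still open speak of the compounds shown alone.

Compound 2 `Cc1ccc(S(=O)(=O)N(Cc2nnc(Cc3ccc(C(F)(F)F)cc3)o2)c2cccc(Cl)c2C)cc1` shows 50.1 nM in an assay on CHO cells for displacement of a labelled ligand from prostaglandin E2 receptor EP1 subtype (Homo sapiens) (on this read-out higher numbers stand for weaker inhibition and lower numbers for stronger inhibition), the highest number of the three measured compounds. Compound 1 `COc1ccc(Cc2nnc(CN(c3cccc(Cl)c3Cl)S(=O)(=O)c3ccc(C)cc3)o2)cc1` gives 7.94 nM and compound 3 `COc1ccc(Cc2nnc(CN(c3cccc(Cl)c3Cl)S(=O)(=O)c3ccc(Cl)cc3)o2)cc1` gives 20 nM in this assay. Within the data shown here, the only single-point step available, a 2.5-fold higher number from compound 1 to compound 3 (0.40 log units; beyond the scatter), concerns the sulfonyl aryl and does not touch the change now considered. Compound 4 `COc1ccc(NCc2nnc(CN(c3cccc(Cl)c3C)S(=O)(=O)c3ccc(C)cc3)o2)cc1` differs from compound 2 in that ((4-methoxyphenyl)amino in place of 4-(trifluoromethyl)phenyl on a saturated chain carbon bound to an aromatic carbon). Among the measured compounds shown here, no measured step bears directly on this change; compound 1, which carries a methoxyphenyl group on the benzylic position, does give a lower number than compound 2, but it differs from compound 2 in two further places. A modest decrease is therefore expected, with wide uncertainty, as a 2.5-fold lower number from compound 2 to compound 4 (0.40 log units; beyond the scatter). Compound 4 is estimated at 20 nM, between 5 nM and 80 nM.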

Compound 4, half-maximal inhibitory concentration: 20 nM
For compound 4 middle estimate and measured number coincide at the digits printed, within the range that was stated.
By their numbers in this assay, from the lowest: compound 1; then compounds 3 and 4 (each within the scatter of the next); then compound 2.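

In this assay, (4-methoxyphenyl)amino in place of 4-(trifluoromethyl)phenyl gives a 2.5-fold lower number from compound 2 to compound 4 (0.40 log units; beyond the scatter). This shows that the saturated chain carbon bound to an aromatic carbon can carry an aryl ring attached through an amino nitrogen, with a lower number than the 4-(trifluoromethyl)phenyl group gives. No available evidence accounts for this step.

The amino nitrogen and the methoxy group enter together, so the compounds shown do not separate their contributions. Going by these compounds, how a plain phenylamino group or a piperidine would fare at this place remains open.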